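Removing the Methoxy Group: From Compound 3 to Compound 4

The source may hold more compounds than are shown below. What is called first, only, known or untested is meant among the compounds shown, and "the series" means these compounds.

Of the compounds shown here, three sharing one core have been tested in a functional assay on HeLa cells (Homo sapiens) for inhibition, read by CCK-8 assay, with a stated time of 48 h; a higher number here means a weaker inhibitor, a lower number a stronger inhibitor. Compound 1 `c1ccc(C2=NN(C3=NC(c4ccccc4)CS3)C(c3cccc4ccccc34)C2)cc1` gives 5320 nM. Compound 2 `Cc1ccc(C2=NN(C3=NC(c4ccccc4)CS3)C(c3ccc4ccccc4c3)C2)cc1`, which carries a methyl group on its phenyl ring and a differently attached naphthalene, gives 2460 nM. Compound 3 `COc1ccc(C2=NN(C3=NC(c4ccccc4)CS3)C(c3ccc4ccccc4c3)C2)cc1`, with a methoxy group in place of that methyl, gives 1860 nM. Among the compounds with values here, the only one-point step among them, a 1.3-fold lower number from compound 2 to compound 3 (0.12 log units; within the scatter), shows that swapping methyl for methoxy made no difference that can be trusted. Compound 3 thus gives the lowest number of the three, but compound 2 sits within the usual scatter of it, while compound 1 lies clearly higher; compound 1 differs from compound 3 in two places, so its gap cannot be pinned on either change alone.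

Compound 4 `c1ccc(C2=NN(C3=NC(c4ccccc4)CS3)C(c3ccc4ccccc4c3)C2)cc1` is compound 3 with the change (hydrogen in place of methoxy on an aromatic carbon). Within the data shown here, no measured step tells what removing this group does here. Among the measured compounds shown here, the one step that bears on the para position, from compound 2 to compound 3, was within scatter, which suggests the substituent at that place matters little. A small step in this assay, a 1.6-fold higher number from compound 3 to compound 4 (0.21 log units; within the scatter), is therefore expected, and compound 4 is estimated at 3000 nM, with a range from 1200 nM to 8000 nM.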

Compound 4, half-maximal inhibitory concentration: 3860 nM
Compound 4: the middle estimate sits 1.3-fold (0.11 log units) below what was measured; low and high end bracket the measured number.
By their numbers in this assay, from the lowest: compounds 3, 2, 4 and 1 (each within the scatter of the next, the first and the last beyond it).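

In this assay, within the data shown here, the change from 4-methoxyphenyl to phenyl gives the first step at this position that clears the usual scatter: a 2.1-fold higher number from compound 3 to compound 4 (0.32 log units; beyond the scatter) is modest but can be trusted. Hydrogen in place of methyl does not clear it, since a 1.6-fold higher number from compound 2 to compound 4 (0.20 log units; within the scatter) stays within the scatter, and a 1.3-fold lower number from compound 2 to compound 3 (0.12 log units; within the scatter) did not clear it either, so only methoxy and hydrogen can be told apart, with methyl not separable from either one. Among these compounds, the result also isolates the naphthalene attachment for the first time, because compound 1 and compound 4 differ only there, and a 1.4-fold lower number from compound 1 to compound 4 (0.14 log units; within the scatter) shows that naphthalen-2-yl in place of naphthalen-1-yl makes no difference that can be trusted when the other ring is a plain phenyl.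

Open questions remain about whether an amine, a hydroxyl or a longer chain such as ethoxy at this place would take the number further from that of compound 4, and whether methoxy would make the same difference on a compound carrying naphthalen-1-yl. No measurement at hand accounts for the difference between methoxy and hydrogen.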